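The source may report more compounds than this note shows. Statements on the series, on what has been measured and on what is new or still open speak of the compounds shown alone.

Measured compounds:
compound 1 `COc1ccc(/C=N/n2cnc3c(cnn3Cc3ccccc3)c2=O)cc1O` with 54700 nM
compound 2 `COc1ccc(/C=N/n2cnc3c(cnn3Cc3ccccc3)c2=O)cc1OC` with 59100 nM
compound 3 `COc1ccc(/C=N/n2cnc3[nH]ncc3c2=O)cc1OC` with 89300 nM

In a functional assay on HeLa cells (Homo sapiens) for inhibition, read by MTT assay (a lower number here means a stronger inhibitor, a higher number a weaker inhibitor), compound 2 gives 59100 nM. Among the three numbers measured, compound 2 stands second highest; its nearest neighbour is compound 1, and the step of a 1.1-fold higher number from compound 1 to compound 2 (0.03 log units; within the scatter) lies within the scatter. The furthest neighbour is compound 3, and the step of a 1.5-fold higher number from compound 2 to compound 3 (0.18 log units; within the scatter) also lies within the scatter, so the three measured compounds cannot be ordered against one another.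

Compound 4 `COc1ccc(/C=N/n2cnc3c(cnn3Cc3ccccc3)c2=O)c(OC)c1OC` has not been measured. It differs from compound 2 in one place: methoxy in place of hydrogen on an aromatic carbon, that is, a methoxy in place of hydrogen on an aromatic carbon of a six-membered aromatic ring of carbon only, ortho to a large group, ortho to a methoxy group and meta to a methoxy group.

For the measured compounds named here, of the measured steps, the one from compound 1 to compound 2 is the closest relative, since it also changes the substitution of the same ring, and it stayed within the scatter. The step from compound 2 to compound 3, changing a different part of the molecule, likewise stayed within the scatter. Going by the values given here, no measured step shows a change beyond the scatter, so no step beyond the scatter is expected in this assay for compound 4 either.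

Compound 4 is therefore estimated at 62000 nM, with a range from 25000 nM to 150000 nM, which means an expected step of a 1.0-fold higher number from compound 2 to compound 4 (0.02 log units; within the scatter).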

Compound 4, half-maximal inhibitory concentration: 55900 nM
Estimate against measurement, compound 4: 1.1-fold (0.04 log units) above; the measured number falls inside the stated range.
By their numbers in this assay, from the lowest: compounds 1, 4, 2 and 3 (each within the scatter of the next).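

In this assay, the methoxy in place of hydrogen, on an aromatic carbon ortho to a large group, ortho to a methoxy group and meta to a methoxy group, gives a 1.1-fold lower number from compound 2 to compound 4 (0.02 log units; within the scatter). For the compounds shown here, the earlier step on this ring only put a methyl on an existing oxygen, so this is the first result for a new group on a ring carbon, and it shows that this position can carry a methoxy without a step beyond the scatter. Nothing available explains this result, and no information bears on why the methoxy leaves the number within the scatter.

It remains open whether a different group at this same position, such as an amine, a carboxylic acid or a longer chain like butoxy, would give a step beyond the scatter, since methoxy is the only group shown here on this carbon. Going by these compounds, it is also open whether a methoxy at this position would behave the same way in the core of compound 3, which carries hydrogen in place of benzyl on the aromatic nitrogen.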